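The source may report more compounds than this note shows. Statements on the series, on what has been measured and on what is new or still open speak of the compounds shown alone.

Going by the values given here, in a toxicity assay on Hepa-1c1c7 cells (Mus musculus) for inhibition (on this read-out lower numbers stand for stronger inhibition and higher numbers for weaker inhibition), compound 1 (`CCCCCCCCCC(O)C#CC#CC(O)CCC`) gives 30000 nM and compound 2 (`CCCCCCCCCC(O)C#CC#CC(O)CCCCCCCCC`) gives 26000 nM as the only other measured number, so compound 1 stands within the scatter of compound 2. Compound 3 (`CCCCCCCCCC(O)C#CC#CC(O)C1CCCCC1`) is still unmeasured, and its difference from compound 1 is cyclohexyl in place of propyl on a saturated chain carbon bound to an oxygen on a saturated carbon and a triple-bonded carbon in the form of cyclohexyl in place of propyl on a saturated chain carbon bound to an oxygen on a saturated carbon and a triple-bonded carbon. Among the compounds with values here, one measured step bears on this: hexyl in place of hydrogen on a saturated chain carbon gave a 1.2-fold lower number from compound 1 to compound 2 (0.06 log units; within the scatter) as the sole guide. Within the data shown here, no measured compound carries a ring, so the guide is thin. No step beyond the scatter is therefore expected in this assay for this change. The estimated move is a 1.2-fold lower number from compound 1 to compound 3 (0.08 log units; within the scatter) and it would stay inside the scatter. For compound 3 the expected value is 25000 nM with an estimated range from 12000 nM to 50000 nM for repeat measurements.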

Compound 3, half-maximal inhibitory concentration: 44000 nM
For compound 3 the middle estimate is 1.8-fold (0.25 log units) below the measured one; the range from low to high includes it.
By their numbers in this assay, from the lowest: compounds 2, 1 and 3 (each within the scatter of the next).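

In this assay, cyclohexyl in place of propyl on a saturated chain carbon bound to an oxygen on a saturated carbon and a triple-bonded carbon gives a 1.5-fold higher number from compound 1 to compound 3 (0.17 log units; within the scatter). Compound 3 is the only compound shown with a ring, so this step extends the earlier chain-only comparison to a six-membered non-aromatic ring of carbon only. Here, the ring and its larger count of heavy atoms do not produce a step beyond the scatter.

Neither step read so far lies beyond the scatter, so no group at this position has yet separated from another. As far as these compounds go, whether a phenyl ring, an amine or a carboxylic acid in this place would move the number beyond the scatter remains open. No supporting data bear on this result.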